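This account rests on a few compounds, and the source may have more. Where it says the series, first, only, none or still open, it means among the compounds named here.

Measured so far in a physicochemical assay for lipophilicity; on this read-out lower numbers stand for lower lipophilicity and higher numbers for higher lipophilicity:
compound 1, `N=C(N)Nc1cccc(C(=O)NNC(=O)NC(CC(=O)O)c2ccc(F)cc2)c1`: 0.86
compound 2, `COc1ccc(C(CC(=O)O)NC(=O)NNC(=O)c2cccc(NC(=N)N)c2)cc1`: 0.58

Within the data shown here, compound 2 stands lowest of the two numbers in this assay; its only neighbour is compound 1, and a number 0.28 log units lower from compound 1 to compound 2 (within the scatter), so the two compounds are not separated beyond the scatter.

Compound 3, `N=C(N)Nc1cccc(C(=O)NNC(=O)NC(CC(=O)O)c2cccc3ccccc23)c1`, has not yet been measured. It differs from compound 2 by naphthalen-1-yl in place of 4-methoxyphenyl on a saturated chain carbon bound to an amide-type nitrogen and a saturated chain carbon. Among the measured compounds shown here, the one measured step, a number 0.28 log units lower from compound 1 to compound 2 (within the scatter), exchanges a small aromatic substituent for another and does not touch a naphthalen-1-yl group, so it bears on the present change only loosely; it shows that swapping the substituent on that ring moved the read-out little. The present change is larger: the leaving group carries one hydrogen-bond acceptor and one ring, the entering group none and two rings. For the measured compounds named here, on those counts an upward step beyond the scatter is expected, though no measured pair fixes its size.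

Compound 3 is therefore expected to give 1.5, within a range of 1 to 2.2. This amounts to an expected step of a number 0.92 log units higher from compound 2 to compound 3 (beyond the scatter).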

Compound 3, partition coefficient: 1.7
Compound 3: middle estimate off by 0.20 log units, on the low side, and the stated range covers the measured number.
By their numbers in this assay, from the lowest: compounds 2 and 1 (each within the scatter of the next); then compound 3.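

At this position, on a saturated chain carbon bound to an amide-type nitrogen and a saturated chain carbon, the read-out in this assay responds strongly to the aromatic group itself and not only to a substituent on it: naphthalen-1-yl in place of 4-methoxyphenyl gives the large step (a number 1.12 log units higher from compound 2 to compound 3 (beyond the scatter)), and naphthalen-1-yl in place of 4-fluorophenyl gives the modest one (a number 0.84 log units higher from compound 1 to compound 3 (beyond the scatter)). The earlier exchange of fluoro and methoxy stayed within the scatter, whereas both new steps lie beyond it, which places compound 3 highest of the three in this assay and clear of both neighbours. Nothing available accounts for the size of these steps.

Still open, going by these compounds, is whether an unsubstituted phenyl or a saturated cyclohexyl at this position would fall with compound 1 and compound 2 or nearer to compound 3, so the second aromatic ring cannot yet be separated from the change of group as a whole. Also open, on these data alone, is whether a step of this size would persist with a methyl ester in place of the carboxylic acid elsewhere on the core.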